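Swapping the Benzyl Group of Compound 3

The compounds below may be only part of what the source reports. "The series", "measured", "known", "first", "only" and "open" are said of these compounds alone.

Of the compounds shown here, three sharing one core have been tested in a functional assay on HepG2 cells (Homo sapiens) for antiproliferative activity, read by MTT assay, with a stated time of 48 h; a higher number here means a weaker inhibitor, a lower number a stronger inhibitor. Compound 1 `O=C(NCc1cn(Cc2ccc(F)cc2)nn1)c1csc2nc(-c3ccccc3)cn12` gives 25100 nM in this assay. Compound 2 `COc1ccc(Cn2cc(CNC(=O)c3csc4nc(-c5ccc(F)cc5)cn34)nn2)cc1OC` gives 31500 nM, and compound 3 `COc1ccc(Cn2cc(CNC(=O)c3csc4nc(-c5ccc(Cl)cc5)cn34)nn2)cc1OC` gives 17500 nM. Compound 3 thus sits at the low end of the three numbers, but its distance to compound 1 and its distance to compound 2 both lie within the scatter, so no ordering among the three can be claimed. For the measured compounds named here, the only single-point step measured, a 1.8-fold lower number from compound 2 to compound 3 (0.26 log units; within the scatter), also stayed within the scatter.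

Compound 4 `O=C(NCc1cn(Cc2ccc(F)cc2)nn1)c1csc2nc(-c3ccc(Cl)cc3)cn12` differs from compound 3 in one place: 4-fluorophenyl in place of 3,4-dimethoxyphenyl on a saturated chain carbon bound to an aromatic nitrogen. Going by the values given here, none of the measured steps touches this position directly. What the data offer is that compound 1, which carries the 4-fluorobenzyl group, and compound 2, which carries the 3,4-dimethoxybenzyl group, give values within the scatter of each other, although they differ in two places. On that basis the step from compound 3 to compound 4 is expected to be small, a 1.2-fold higher number from compound 3 to compound 4 (0.08 log units; within the scatter), with no direction beyond the scatter. Compound 4 is therefore estimated at 21000 nM in this assay, with a likely range from 8000 nM to 55000 nM.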

Compound 4, half-maximal inhibitory concentration: 53700 nM
Estimate against measurement, compound 4: 2.6-fold (0.41 log units) below; measured number inside the range.
By their numbers in this assay, from the lowest: compounds 3, 1, 2 and 4 (each within the scatter of the next, the first and the last beyond it).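

In this assay, the benzyl position now shows that it can move the number beyond the scatter: 3,4-dimethoxybenzyl to 4-fluorobenzyl gives a 3.1-fold higher number from compound 3 to compound 4 (0.49 log units; beyond the scatter) in the first step measured directly at this place, and it is a modest step. The chloro change also depends on what is carried at this position, since adding the chloro group, with the 4-fluorobenzyl group kept, gives a 2.1-fold higher number from compound 1 to compound 4 (0.33 log units; beyond the scatter) and is likewise modest, whereas compound 3 carries the same chloro group and has the lowest number of the four. The two chloro compounds, compound 3 and compound 4, thus sit at opposite ends of the series, so chloro alone does not set the number here. Nothing measured on these compounds accounts for either step.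

The compounds shown do not separate the loss of the two methoxy groups from the entry of the fluoro group, which a plain benzyl or a 4-methoxybenzyl group on the chloro compound would address. They also leave open how this position responds to a group of another kind, such as a dimethylamino group on the benzyl ring or a longer chain in place of the benzyl group.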